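From Hydroxyl to Ketone on a Long Lipid Chain

A few compounds are considered here, and "the series" means these few. Any claim that something is new, unique, unknown or untested is made for them only; others in the source may bear on it.

Compound 1 `CCCCCCCC/C=C\CCCCCCCCCCC(=O)NCc1ccc(O)c(OC)c1`: 3.16 nM
Compound 2 `CCCCCC[C@@H](O)CCCCCCCCCCC(=O)NCc1ccc(O)c(OC)c1`: 5.01 nM

Both compounds were tested in a functional assay on HEK293 cells with transient receptor potential cation channel subfamily V member 1 (Homo sapiens) as the target; a higher number here means that more compound is needed for the effect, a lower number that less compound is needed. Compound 1 gives 3.16 nM and compound 2 gives 5.01 nM; the step of a 1.6-fold higher number from compound 1 to compound 2 (0.20 log units; within the scatter) is within the scatter, so the two values cannot be told apart. Among the compounds with values here, compound 2 stands as the higher of the two numbers, with compound 1 its only neighbour.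

Compound 3 `CCCCCCC(=O)CCCCCCCCCCC(=O)NCc1ccc(O)c(OC)c1` differs from compound 2 by hexylcarbonyl in place of 1-hydroxyheptyl on a saturated chain carbon, ten or more bonds along the chain from a carbonyl carbon: the hydroxyl-bearing carbon becomes a carbonyl at the same position on the chain. Within the data shown here, only one measured step touches this part of the chain, and that step was within the scatter. With so little bearing on this change, the expectation is for no step beyond the scatter, perhaps a slight rise, in this assay.

The estimate for compound 3 is a step of a 1.3-fold higher number from compound 2 to compound 3 (0.10 log units; within the scatter), giving an expected value of 6.3 nM, with a range from 2 nM to 20 nM.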

Compound 3, half-maximal effective concentration: 6.31 nM
Compound 3: middle estimate off by 1.0-fold (0.00 log units), on the low side; the measured number falls inside the stated range.
By their numbers in this assay, from the lowest: compounds 1, 2 and 3 (each within the scatter of the next).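

Replacing 1-hydroxyheptyl with hexylcarbonyl removes a hydrogen-bond donor and the defined stereocentre and adds a double bond outside aromatic rings, yet this assay shows only a 1.3-fold higher number from compound 2 to compound 3 (0.10 log units; within the scatter) for this change. Hexylcarbonyl in place of dec-1-en-1-yl gives a 2.0-fold higher number from compound 1 to compound 3 (0.30 log units; within the scatter) in the same assay, so the three groups tried on this saturated chain carbon cannot be told apart by their numbers. No independent measurement is available to explain why these numbers stay so close.

As far as these compounds go, it remains open whether any group at this place can shift the number beyond the scatter. An amine, a carboxylic acid or a longer chain here would test how much change this part of the molecule tolerates.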